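A methoxyphenyl amine returns to the shared core

The compounds below may be only part of what the source reports. "The series", "measured", "known", "first", "only" and "open" are said of these compounds alone.

Three compounds share one core. Compound 1 `COc1ccc(Nc2cc(C)nc(SCc3nc4ccccc4[nH]3)n2)cc1` carries a (4-methoxyphenyl)amino group, and in a functional assay on PC-3 cells (Homo sapiens) for cytotoxicity, read by MTT assay, with a stated time of 72 h (a higher number here means a weaker inhibitor, a lower number a stronger inhibitor), compound 1 gives 67400 nM. Compound 2 `Cc1cc(NCCO)nc(SCc2nc3ccccc3[nH]2)n1` carries a (2-hydroxyethyl)amino group in its place. In this assay compound 2 reaches only the limit of > 100000 nM. Compound 3 `Cc1cc(N2CCNCC2)nc(SCc2nc3ccccc3[nH]2)n1` carries piperazin-1-yl. In this assay compound 3 likewise reaches only the limit of > 100000 nM. Compound 3 thus stands at the limit of > 100000 nM in this assay, at which 2 of the 3 values shown sit, so its true number is not known, only that it is not below that limit.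

Compound 4 `COc1ccccc1Nc1cc(C)nc(SCc2nc3ccccc3[nH]2)n1` differs from compound 3 by (2-methoxyphenyl)amino in place of piperazin-1-yl on an aromatic carbon. The nearest measured step runs the other way: an at least 1.4-fold higher number from compound 1 to compound 3 (0.17 log units; that floor lies within the scatter). In the same sense, an at least 1.4-fold higher number from compound 1 to compound 2 (0.17 log units; that floor lies within the scatter), while a step that the two limits leave unreadable from compound 2 to compound 3. Going back from piperazin-1-yl to a (2-methoxyphenyl)amino group is therefore expected to bring the number down modestly, toward what compound 1 shows. Compound 4 is expected to give about 70000 nM, between 30000 nM and 150000 nM. The expected step is an at least 1.4-fold lower number from compound 3 to compound 4 (0.15 log units; that floor lies within the scatter).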

Compound 4, half-maximal inhibitory concentration: 70800 nM
Compound 4: the middle estimate sits 1.0-fold (0.00 log units) below what was measured; the measured number falls inside the stated range.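

Moving the methoxy group on the phenyl ring changes nothing that can be read in this assay: compound 1 and compound 4 cannot be told apart (a 1.1-fold higher number from compound 1 to compound 4 (0.02 log units; within the scatter)). So this position tolerates 2-methoxyphenyl as well as 4-methoxyphenyl on the nitrogen, and the two compounds with a methoxyphenyl amine give the only exact numbers in the set. Against the other two groups only floors can be read (an at least 1.4-fold lower number from compound 3 to compound 4 (0.14 log units; that floor lies within the scatter); an at least 1.4-fold lower number from compound 2 to compound 4 (0.14 log units; that floor lies within the scatter)), and compound 2 and compound 3 each rest on a limit rather than a number: the limit of > 100000 nM in this assay, at which 2 of the 4 values shown sit.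

As far as these compounds go, how far compound 4 truly lies from compound 2 and compound 3 stays unknown. Also open, from the compounds shown here alone, is whether the methoxy group matters at all, which a plain phenylamino group or a chlorophenylamino group at this position would help to show.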